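The compounds below may be only part of what the source reports. "The series", "measured", "known", "first", "only" and "open" are said of these compounds alone.

Measured in a functional assay on RAW264.7 cells (Mus musculus) for inhibition; a lower number here means a stronger inhibitor, a higher number a weaker inhibitor:
- compound 1 `O=C(NS(=O)(=O)c1ccc(F)cc1)c1ccncc1`: 9200 nM
- compound 2 `O=C(NS(=O)(=O)c1ccc(Br)cc1)c1ccncc1`: 5500 nM
- compound 3 `Cc1ccc(S(=O)(=O)NC(=O)c2ccncc2)cc1`: 9800 nM

Compound 3, at 9800 nM, cannot be separated from the other two: a 1.1-fold higher number from compound 1 to compound 3 (0.03 log units; within the scatter) and a 1.8-fold higher number from compound 2 to compound 3 (0.25 log units; within the scatter). Compound 4 `Cc1ccc(S(=O)(=O)NC(=O)c2ccccn2)cc1` carries pyridin-2-yl in place of pyridin-4-yl on a carbonyl carbon. The measured steps, including a 1.7-fold lower number from compound 1 to compound 2 (0.22 log units; within the scatter), exchange fluoro, bromo and methyl on an aromatic carbon and keep pyridin-4-yl throughout. They bear on this change only indirectly, and no measurement shows its direction. The expected outcome is a 1.0-fold higher number from compound 3 to compound 4 (0.01 log units; within the scatter), with no step beyond the scatter anticipated. For compound 4 the estimate is 10000 nM, with an expected range of 3500 nM to 30000 nM.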

Compound 4, half-maximal inhibitory concentration: 5900 nM
The estimate for compound 4 lay 1.7-fold (0.23 log units) above the measured number, within the range that was stated.
By their numbers in this assay, from the lowest: compounds 2, 4, 1 and 3 (each within the scatter of the next).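

In this assay, pyridin-2-yl in place of pyridin-4-yl on a carbonyl carbon gives a 1.7-fold lower number from compound 3 to compound 4 (0.22 log units; within the scatter). This place therefore takes the exchange between these two groups without a step beyond the scatter, which the fluoro, bromo and methyl exchanges could not address. Nothing at hand accounts for the result.

Open, going by these compounds, is whether phenyl, pyridin-3-yl or an amine-bearing ring on that carbonyl carbon would give a step beyond the scatter. Also open, on these data alone, is whether pyridin-2-yl gives the same picture with fluoro or bromo in place of methyl.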